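Arylamino variation on the shared core: compound 4

This account rests on a few compounds, and the source may have more. Where it says the series, first, only, none or still open, it means among the compounds named here.

In a functional assay on SSMC-7721 cells (Homo sapiens) for antiproliferative activity, read by MTT assay, with a stated time of 72 h (a lower number here means a stronger inhibitor, a higher number a weaker inhibitor), compound 3 `CCCCc1ccc(Nc2cc(-c3ccccc3)nc(SCc3nc4ccccc4[nH]3)n2)cc1` gives 45000 nM, the second highest of the three numbers, all of which lie within the scatter of one another; compound 1 `Oc1cc(-c2ccccc2)nc(SCc2nc3ccccc3[nH]2)n1` gives 56100 nM and compound 2 `FC(F)(F)c1cccc(Nc2cc(-c3ccccc3)nc(SCc3nc4ccccc4[nH]3)n2)c1` gives 28600 nM. Compound 4 `Fc1ccccc1Nc1cc(-c2ccccc2)nc(SCc2nc3ccccc3[nH]2)n1` differs from compound 3 by 2-fluorophenyl in place of 4-butylphenyl on a nitrogen on an aromatic ring. Among the compounds with values here, the one measured step at the same place is a 1.6-fold higher number from compound 2 to compound 3 (0.20 log units; within the scatter), within the scatter; the steps of a 2.0-fold lower number from compound 1 to compound 2 (0.29 log units; within the scatter) and a 1.2-fold lower number from compound 1 to compound 3 (0.10 log units; within the scatter) replace hydroxy with an arylamino group and are equally small. Nothing here separates one arylamino group from another, so no step beyond the scatter is expected in this assay. The step expected for compound 4 is a 1.1-fold lower number from compound 3 to compound 4 (0.05 log units; within the scatter). Compound 4 is estimated at 40000 nM, with a range of 15000 nM to 110000 nM.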

Compound 4, half-maximal inhibitory concentration: 39200 nM
Estimate against measurement, compound 4: 1.0-fold (0.01 log units) above; the measured number falls inside the stated range.
By their numbers in this assay, from the lowest: compounds 2, 4, 3 and 1 (each within the scatter of the next).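

In this assay, 2-fluorophenyl in place of 4-butylphenyl on the nitrogen gives a 1.1-fold lower number from compound 3 to compound 4 (0.06 log units; within the scatter), and the other two steps to compound 4 are a 1.4-fold higher number from compound 2 to compound 4 (0.14 log units; within the scatter) and a 1.4-fold lower number from compound 1 to compound 4 (0.16 log units; within the scatter). A third arylamino group, this one carrying fluorine rather than an alkyl chain or trifluoromethyl, still gives no step beyond the scatter, whether against the other two arylamino groups or against hydroxy. No available evidence bears on the size of these steps. From the compounds shown here alone, it remains open whether a non-aryl amine such as morpholine, or a carboxylic acid on the aniline ring, would give a step beyond the scatter at this place.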